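The source may report more compounds than this note shows. Statements on the series, on what has been measured and on what is new or still open speak of the compounds shown alone.

Compounds measured so far:

Compound 1, `COc1ccc(/C=C/C2CC(=O)C=CO2)cc1OC`: 145 uM
Compound 2, `COc1cc(/C=C/C2CC(=O)C=CO2)cc(OC)c1OC`: 125 uM
Compound 3, `O=C1C=CCC(/C=C/c2ccc(C(F)(F)F)cc2)O1`: 44.5 uM

In a functional assay on 786-0 cells (Homo sapiens) for inhibition, read by sulforhodamine B assay, with a stated time of 48 h (on this read-out higher numbers stand for weaker inhibition of growth and lower numbers for stronger inhibition of growth), compound 3 gives the lowest of the three numbers, with compound 2 the nearest and compound 1 the furthest, both gaps beyond the scatter. Compound 4, `COc1ccc(/C=C/C2CC=CC(=O)O2)cc1`, has not yet been measured. It differs from compound 3 by methoxy in place of trifluoromethyl on an aromatic carbon.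

For the measured compounds named here, only one measured step exists, a 1.2-fold lower number from compound 1 to compound 2 (0.06 log units; within the scatter), and it concerns a methoxy entering in place of hydrogen, not in place of trifluoromethyl, so no measured step bears directly on the present change. What the data do show is that the two compounds carrying methoxy on the aromatic ring, compound 1 and compound 2, both give higher numbers in this assay than compound 3, which carries trifluoromethyl. On that basis compound 4 is expected to move upward, toward weaker inhibition of growth, by a 2.5-fold higher number from compound 3 to compound 4 (0.39 log units; beyond the scatter). The expected value for compound 4 is estimated at 110 uM, within a range from 55 uM to 220 uM.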

Compound 4, concentration for growth inhibition (reported as GI): 21.6 uM
The estimate for compound 4 lay 5.1-fold (0.71 log units) above the measured number; the measured number lies below the stated range.
By their numbers in this assay, from the lowest: compound 4; then compound 3; then compounds 2 and 1 (each within the scatter of the next).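

In this assay, for the compounds shown here, the exchange on an aromatic carbon para to a group of 9 heavy atoms gives a 2.1-fold lower number from compound 3 to compound 4 (0.31 log units; beyond the scatter), so methoxy in place of trifluoromethyl at this position lowers the number by a modest step, the first measured step that exceeds the scatter. Going by these compounds alone, compounds 1 and 2 also carry methoxy and give higher numbers, but each differs from compound 4 in more than one place, including the core, so their values say nothing about this exchange, and only the pair of compound 3 and compound 4 isolates it. No measured evidence accounts for the direction or size of the step, which therefore stands as an observation only.

The compounds shown leave open how an amine, a carboxylic acid or a plain hydrogen at this same position would compare with methoxy and trifluoromethyl, since two groups alone define no trend there. Within the data shown here, they also leave open whether the same exchange would give a step of similar direction and size on the core of compound 1, where no pair with trifluoromethyl and methoxy at this position is available.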